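Swapping a Methoxyphenyl Ketone for a Difluorophenyl Ketone

The source may report more compounds than this note shows. Statements on the series, on what has been measured and on what is new or still open speak of the compounds shown alone.

Measured in a functional assay on SK-OV-3 cells (Homo sapiens) for inhibition, read by sulforhodamine B assay, with a stated time of 48 h; a lower number here means that less compound is tolerated, a higher number that more compound is tolerated:

Compound 1 `COc1cc(-c2cc(/C=C/C(=O)c3ccc(N)cc3)[nH]n2)cc(OC)c1OC` gives 28900 nM.
Compound 2 `COc1cc(-c2cc(/C=C/C(=O)c3ccc(Cl)c(Cl)c3)[nH]n2)cc(OC)c1OC` gives 62500 nM.
Compound 3 `COc1ccc(C(=O)/C=C/c2cc(-c3cc(OC)c(OC)c(OC)c3)n[nH]2)cc1` gives > 100000 nM, which is a limit of the assay rather than a number.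

All three share one core and differ only in the aryl group on the carbonyl carbon. Compound 3 stands at the top of the range shown: it sits at the limit of > 100000 nM in this assay, at which 1 of the 3 values shown sits, so only a lower bound for its number is known. Compound 4 `COc1cc(-c2cc(/C=C/C(=O)c3ccc(F)c(F)c3)[nH]n2)cc(OC)c1OC` is made from compound 3 by one change: 3,4-difluorophenyl in place of 4-methoxyphenyl on a carbonyl carbon.

The step that bears most directly on this change is an at least 1.6-fold higher number from compound 2 to compound 3 (0.20 log units; that floor lies within the scatter), since the new compound carries a dihalogenated ring much like compound 2. Read in reverse, that step points toward a somewhat lower number for compound 4 than for compound 3, though its floor lies within the scatter. The other step, a 2.2-fold higher number from compound 1 to compound 2 (0.33 log units; beyond the scatter), shows that a dihalogenated ring can also sit higher than an aminophenyl ring. Taken together, a small downward move is expected, an at least 1.6-fold lower number from compound 3 to compound 4 (0.22 log units; that floor lies within the scatter). Compound 4 is therefore estimated at 60000 nM, within the range 25000 nM to 150000 nM.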

Compound 4, concentration lethal to 50% of the cells: > 100000 nM
Compound 4: a limit, no number; the forecaster's own chance of this, stated with the estimate: 35%; middle value at least 1.6-fold (0.22 log units) from the limit.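

In this assay, 3,4-difluorophenyl on the carbonyl carbon reaches the same ceiling as 4-methoxyphenyl, so a ring with two halogens does not have to read lower than the methoxy ring: the limit of > 100000 nM in this assay, at which 2 of the 4 values shown sit.

Placing 3,4-difluorophenyl in place of 3,4-dichlorophenyl gives an at least 1.6-fold higher number from compound 2 to compound 4 (0.20 log units; that floor lies within the scatter), so these values do not establish a real difference between the two halogenated rings. The comparison with the amino ring is clearer, with an at least 3.4-fold higher number from compound 1 to compound 4 (0.53 log units; beyond the scatter), which shows that this change of aryl group can move the number beyond the scatter.

As far as these compounds go, compound 3 and compound 4 both stand at a limit, so the step between them cannot be read and their true order stays open. From the compounds shown here alone, how an aryl group carrying a carboxylic acid or a nitrile would read in this assay also remains open.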